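Swapping the benzyl group on the triazole of compound 3

A few compounds are considered here, and "the series" means these few. Any claim that something is new, unique, unknown or untested is made for them only; others in the source may bear on it.

Measured so far:
- Compound 1 `COc1ccc(Cn2cc(CNC(=O)c3cn(-c4ccccc4)nc3-c3ccc(Cl)cc3)nn2)cc1OC`, in a functional assay on HeLa cells (Homo sapiens) for antiproliferative activity, read by sulforhodamine B assay, with a stated time of 48 h (a higher number here means a weaker inhibitor of growth, a lower number a stronger inhibitor of growth), compound 1 gives 200 nM
- Compound 2 `COc1ccc(-c2nn(-c3ccccc3)cc2C(=O)NCc2cn(Cc3ccc(F)cc3)nn2)cc1`, in this assay compound 2 gives 500 nM
- Compound 3 `COc1ccc(-c2nn(-c3ccccc3)cc2C(=O)NCc2cn(Cc3ccc(Cl)cc3)nn2)cc1`, in this assay compound 3 gives 6400 nM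

Compound 3 has the highest number of the three, so it is the weakest growth inhibitor among them; its nearest neighbour is compound 2, and compound 1 lies further away still. Going by the values given here, the only one-place step measured so far is a 13-fold higher number from compound 2 to compound 3 (1.11 log units; beyond the scatter), which shows that a small change on the benzyl group attached to the triazole can move this read-out a long way.

Compound 4 `COc1ccc(-c2nn(-c3ccccc3)cc2C(=O)NCc2cn(Cc3ccc(OC)c(OC)c3)nn2)cc1` carries the change (3,4-dimethoxyphenyl in place of 4-chlorophenyl on a saturated chain carbon bound to an aromatic nitrogen). Among the compounds with values here, no measured pair isolates exactly this swap. Still, compound 1 carries the same 3,4-dimethoxybenzyl group on its triazole and sits far below compound 3, and the step from compound 2 to compound 3 shows this position to be sensitive. Compound 4 is therefore expected to give a clearly lower number, a step of a 16-fold lower number from compound 3 to compound 4 (1.20 log units; beyond the scatter), with an estimate of 400 nM and a range from 100 nM to 2000 nM.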

Compound 4, concentration for 50% growth inhibition: 800 nM
Compound 4: middle estimate off by 2.0-fold (0.30 log units), on the low side; measured number inside the range.
By their numbers in this assay, from the lowest: compound 1; then compounds 2 and 4 (each within the scatter of the next); then compound 3.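

Changing the 4-chlorobenzyl group to 3,4-dimethoxybenzyl gives an 8.0-fold lower number from compound 3 to compound 4 (0.90 log units; beyond the scatter) in this assay and so recovers much of the ground lost with the chloro compound. Measured against the 4-fluorobenzyl group, the same dimethoxy group gives a 1.6-fold higher number from compound 2 to compound 4 (0.20 log units; within the scatter) and stays within the scatter, so among these three benzyl groups only 4-chlorobenzyl stands apart, with the weakest growth inhibition. With the 3,4-dimethoxybenzyl group held constant, a 4.0-fold higher number from compound 1 to compound 4 (0.60 log units; beyond the scatter) follows from methoxy in place of chloro on an aromatic carbon, which shows that a change elsewhere on the shared core also moves this read-out.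

Nothing measured here accounts for why the chloro compound stands apart. Going by these compounds, it also remains open how the read-out would respond to an amine or a carboxylic acid on the benzyl ring, or to a longer chain in place of the benzyl carbon.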